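From thiophen-2-yl to pyridin-4-yl at the saturated ring carbon

The source may hold more compounds than are shown below. What is called first, only, known or untested is meant among the compounds shown, and "the series" means these compounds.

Of the compounds shown here, three sharing one core have been measured in a functional assay on PC-3 cells (Homo sapiens) for cytotoxicity, read by WST assay, with a stated time of 72 h; a lower number here means a stronger inhibitor, a higher number a weaker inhibitor. Compound 1 `Cc1ccc(C2(c3ccc(O)cc3)C(=O)Nc3c2ccc(F)c3F)cc1` gives 0.8 nM, compound 2 `CCOc1ccc(C2(c3ccc(O)cc3)C(=O)Nc3c2ccc(F)c3F)cc1` gives 24 nM, and compound 3 `O=C1Nc2c(ccc(F)c2F)C1(c1ccc(O)cc1)c1cccs1` gives 0.3 nM, the lowest number of the three.

Compound 4 `O=C1Nc2c(ccc(F)c2F)C1(c1ccncc1)c1ccc(O)cc1` carries pyridin-4-yl in place of thiophen-2-yl on a saturated ring carbon.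

Two measured steps change the group on that same carbon: a 2.7-fold lower number from compound 1 to compound 3 (0.43 log units; beyond the scatter), which is modest, and an 80-fold lower number from compound 2 to compound 3 (1.90 log units; beyond the scatter), which is large. A third, a 30-fold higher number from compound 1 to compound 2 (1.48 log units; beyond the scatter), is also large and swaps methyl for ethoxy on an aromatic carbon. Within the data shown here, no measured compound carries pyridin-4-yl, so the data offer only an indirect guide. Both steps at this carbon end at compound 3, so any replacement of its thiophen-2-yl is expected to raise the number, by a modest to large amount. The expected change is a 10-fold higher number from compound 3 to compound 4 (1.00 log units; beyond the scatter). Compound 4 is estimated at 3 nM, within a range of 0.5 nM to 20 nM.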

Compound 4, half-maximal inhibitory concentration: 110 nM
Compound 4: middle estimate off by 37-fold (1.56 log units), on the low side; measured number outside the range, above it.
By their numbers in this assay, from the lowest: compound 3; then compound 1; then compound 2; then compound 4.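

In this assay, among these compounds, the change to pyridin-4-yl on the saturated ring carbon gives a 370-fold higher number from compound 3 to compound 4 (2.56 log units; beyond the scatter) and is the largest step yet seen at that carbon, so the position tolerates less than the earlier compounds suggested. Those compounds had put 4-ethoxyphenyl at the high end, yet pyridin-4-yl lies past it with a 4.6-fold higher number from compound 2 to compound 4 (0.66 log units; beyond the scatter) and far past 4-methylphenyl with a 140-fold higher number from compound 1 to compound 4 (2.14 log units; beyond the scatter) even though it carries neither an ethoxy nor a methyl group. Thiophen-2-yl and pyridin-4-yl are each one aromatic ring with one hetero atom and have the same hydrogen-bond counts, and no measurement here accounts for the gap between them.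

Open, from the compounds shown here alone, is whether pyridin-3-yl or pyridin-2-yl would stand nearer compound 3 or compound 4. Also open, going by these compounds, is how an unsubstituted phenyl or a furan-2-yl ring would behave at this carbon.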